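The source may hold more compounds than are shown below. What is called first, only, known or untested is meant among the compounds shown, and "the series" means these compounds.

Among the measured compounds shown here, in a functional assay on HepG2 cells (Homo sapiens) for inhibition, read by fluorescence and resazurin assay, with a stated time of 72 h (a lower number here means a stronger inhibitor, a higher number a weaker inhibitor), compound 1 (`O=C(Nc1ccccc1)Nc1cccc(Nc2nccc(Nc3ccc4cn[nH]c4c3)n2)c1`) reads 8200 nM as the lower of the two numbers so far. Compound 2 (`O=C(Nc1ccccc1)Nc1cc(Nc2nccc(Nc3ccc4cn[nH]c4c3)n2)ccc1O`) reads 25000 nM and holds the highest number, which makes it the weaker inhibitor of the pair. For the measured compounds named here, the one measured step, a 3.0-fold higher number from compound 1 to compound 2 (0.48 log units; beyond the scatter), comes with hydroxy in place of hydrogen on an aromatic carbon. Compound 3 (`Cc1ccc(Nc2nccc(Nc3ccc4cn[nH]c4c3)n2)cc1NC(=O)Nc1ccccc1`) has methyl in place of hydroxy on that same carbon (methyl in place of hydroxy on an aromatic carbon), which is ortho to a (phenylcarbamoyl)amino group and para to a large group.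

Going by the values given here, only that one step bears on the change, and no methyl compound has been measured. Compound 3 loses the hydroxy that separates compound 2 from compound 1 in a 3.0-fold higher number from compound 1 to compound 2 (0.48 log units; beyond the scatter), so a return toward the number of compound 1 seems likely, though methyl is not hydrogen. Expected in this assay is a 2.8-fold lower number from compound 2 to compound 3 (0.44 log units; beyond the scatter) as a modest step to a lower number. The estimate for compound 3 is 9000 nM with an expected range from 3000 nM to 25000 nM in this assay.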

Compound 3, half-maximal inhibitory concentration: 8900 nM
Beside the measured number, compound 3's estimate is 1.0-fold (0.00 log units) above it, and the stated range covers the measured number.
By their numbers in this assay, from the lowest: compounds 1 and 3 (each within the scatter of the next); then compound 2.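

In this assay, the carbon ortho to a (phenylcarbamoyl)amino group and para to a large group can now be read with three different occupants, and hydroxy is the one that stands apart: methyl in place of hydroxy gives a 2.8-fold lower number from compound 2 to compound 3 (0.45 log units; beyond the scatter), whereas methyl in place of hydrogen gives a 1.1-fold higher number from compound 1 to compound 3 (0.04 log units; within the scatter) and so leaves the reading unresolved from the unsubstituted compound. The higher number of compound 2 therefore goes with hydroxy itself and not with the mere presence of a substituent on this carbon, at least as far as methyl is a fair test of that. Nothing at hand gives a measured reason for the gap between hydroxy and methyl at this position.

Still open, as far as these compounds go, is whether other small groups on this carbon, such as an amine, a methoxy group or a fluorine atom, would read with hydrogen and methyl or with hydroxy. Also open, from the compounds shown here alone, is whether a longer chain here would hold the same reading, and whether the change from hydroxy to methyl gives a similar step on other carbons of this ring.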